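The source may report more compounds than this note shows. Statements on the series, on what has been measured and on what is new or still open speak of the compounds shown alone.

Measured in a functional assay on MIA PaCa-2 cells (Homo sapiens) for antiproliferative activity, read by MTT assay, with a stated time of 24 h; on this read-out lower numbers stand for stronger inhibition and higher numbers for weaker inhibition:
compound 1 `c1ccc(-c2noc(-c3ccncc3)n2)cc1`: 497000 nM
compound 2 `COc1ccc(-c2noc(-c3ccc(F)cc3)n2)cc1O`: 351000 nM
compound 3 `COc1ccc(-c2noc(-c3cccnc3)n2)cc1OC1CCCC1`: > 1000000 nM

Compound 3 stands apart from the other two: its value in this assay is a limit, (the limit of > 1000000 nM in this assay, at which 1 of the 3 values shown sits), not a number. Among the compounds with values here, compound 1 and compound 2 each give a number, but neither differs from compound 3 in one place, so no measured step frames the change to compound 4 `COc1ccc(-c2noc(-c3ccc(F)cc3)n2)cc1OC1CCCC1`, which differs from compound 3 by 4-fluorophenyl in place of pyridin-3-yl on an aromatic carbon. Compound 2 carries the same 4-fluorophenyl on the shared core and gives a number in this assay. Compound 4 is therefore expected to move into the measurable range, with an at least 1.6-fold lower number from compound 3 to compound 4 (0.22 log units; that floor lies within the scatter) as the expected step, though a limit remains possible. Compound 4 is estimated at 600000 nM, between 200000 nM and 2000000 nM.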

Compound 4, half-maximal inhibitory concentration: 6090 nM
Beside the measured number, compound 4's estimate is 99-fold (1.99 log units) above it; measured number below the stated range.
By their numbers in this assay, from the lowest: compound 4; then compounds 2 and 1 (each within the scatter of the next). At a limit, above all of these: compound 3.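

With cyclopentyl on the oxygen kept, 4-fluorophenyl in place of pyridin-3-yl on this aromatic carbon gives an at least 160-fold lower number from compound 3 to compound 4 (2.21 log units; beyond the scatter) in this assay. The value of compound 3 is a limit, not a number: the limit of > 1000000 nM in this assay, at which 1 of the 4 values shown sits.

With 4-fluorophenyl kept, cyclopentyl in place of hydrogen on the oxygen gives a 58-fold lower number from compound 2 to compound 4 (1.76 log units; beyond the scatter), so the low number of compound 4 comes with both groups together.

Open, going by these compounds, is whether the fluorine is needed: a plain phenyl on this carbon, with cyclopentyl kept, would separate it from the change of ring. Equally open, on these data alone, is whether cyclopentyl can give way to a longer chain such as n-butyl or to a chain ending in an amine.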